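Working notes on a phospholipase series: compound 4

A few compounds are considered here, and "the series" means these few. Any claim that something is new, unique, unknown or untested is made for them only; others in the source may bear on it.

All three measured compounds were tested in an assay on COS-7 cells for inhibition of patatin-like phospholipase domain-containing protein 2 (Mus musculus), tested at 200 uM; on this read-out lower numbers stand for less inhibition and higher numbers for more inhibition at the one concentration tested (going by the name of the read-out):
- compound 1 `CCOC(=O)c1cccc(-c2ccc(CN3CCCC3)cc2)c1` gives 33%
- compound 2 `CCOC(=O)c1cccc(-c2ccc(OCC)c(N)c2)c1` gives 59%
- compound 3 `CCNS(=O)(=O)c1cccc(-c2ccc(OCC)cc2)c1` gives 46%

Compound 3 stands second highest of the three numbers. Its nearest neighbour is compound 1, lower by a gap beyond the scatter; compound 2 lies higher by a gap of the same size, also beyond the scatter. The next compound, compound 4 `CCCCOC(=O)c1cccc(-c2ccc(OCC)cc2)c1`, differs from compound 3 in one place: butoxycarbonyl in place of ethylsulfamoyl on an aromatic carbon. Among the measured compounds shown here, no pair of measured compounds carries this change, so there is no measured step to lean on; the two other compounds bracket compound 3 on either side. The expected step of a number 2 percentage points higher from compound 3 to compound 4 (within the scatter) in this assay is therefore small, not beyond the scatter in either direction. Compound 4 is estimated at 48%, within 30% to 66%.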

Compound 4, a percentage reported as inhibition, at one concentration (the size of the read-out at that concentration, not a potency): 61%
Beside the measured number, compound 4's estimate is 13 percentage points below it; measured number inside the range.
By their numbers in this assay, from the lowest: compound 1; then compound 3; then compounds 2 and 4 (each within the scatter of the next).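

In this assay the aromatic carbon carrying ethylsulfamoyl proves sensitive to its substituent: butoxycarbonyl in its place gives a step beyond the scatter (a number 15 percentage points higher from compound 3 to compound 4 (beyond the scatter)). This single change alters the chain, the carbon count and the hydrogen-bond donor together, so the step cannot be assigned to any one of these differences. No measured evidence bears on what lies behind the step.

Open, from the compounds shown here alone, is how a carboxylic acid or a primary amide would read at this position on the shared core. Also open, going by these compounds, is whether a longer chain on the ester would move the number further.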